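The source may hold more compounds than are shown below. What is called first, only, known or untested is meant among the compounds shown, and "the series" means these compounds.

Measured compounds in an ADME assay on MDBK cells (Bos taurus) for cytotoxicity; on this read-out higher numbers stand for lower toxicity in this test and lower numbers for higher toxicity in this test:
- Compound 1 `Cc1ccn(Cc2c(F)cccc2F)c2nc(-c3c(F)cccc3F)nc1-2`: compound 1 gives > 100000 nM, a limit of the assay.
- Compound 2 `Cc1ccc(Cn2ccc3nc(-c4ccccc4)nc-3c2)cc1`: compound 2 gives > 100000 nM, a limit of the assay.
- Compound 3 `N#Cc1ccccc1Cn1ccc2nc(-c3ccccc3)nc-2c1`: compound 3 gives > 100000 nM, a limit of the assay.

Compound 2 therefore stands only as a limit in this assay, and the same holds for the other two values: the limit of > 100000 nM in this assay, at which 3 of the 3 values shown sit. Compound 4 `CCC(CC)Cn1ccc2nc(-c3ccccc3)nc-2c1` differs from compound 2 by pentan-3-yl in place of 4-methylphenyl on a saturated chain carbon bound to an aromatic nitrogen. Among the measured compounds shown here, the only measured step at the same place, a step that the two limits leave unreadable from compound 2 to compound 3, is unreadable, so its size gives no guide. No readable step is expected in this assay; compound 4 is expected to sit at the limit as well. Compound 4 is estimated at 100000 nM, within 50000 nM to 200000 nM. This corresponds to an expected step of a number no higher from compound 2 to compound 4 (the limit leaves the size open).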

Compound 4, half-maximal cytotoxic concentration: > 100000 nM
Compound 4 ended at the assay's limit; the forecaster's own chance of this, stated with the estimate: 80%; the middle value sits exactly at the limit.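

The steps among compound 2, compound 3 and compound 4 cannot be read in this assay, as each value is only a limit of the assay: the limit of > 100000 nM in this assay, at which 4 of the 4 values shown sit.

Whether any group at this place shifts the read-out at all stays open, with no compound shown giving a value inside the assay's range.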